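Quinolin-2-amine analogue with added 4-methylphenyl: expected cytotoxicity

The compounds below may be only part of what the source reports. "The series", "measured", "known", "first", "only" and "open" are said of these compounds alone.

Three anilines sharing a 4-methoxyphenylamino group have been measured in a functional assay on Fem-X cells (Homo sapiens) for cytotoxicity, read by MTT assay, with a stated time of 72 h; on this read-out lower numbers stand for stronger inhibition and higher numbers for weaker inhibition. Compound 1 `COc1ccc(Nc2ccc3ccccc3n2)cc1` gives 43000 nM in this assay. Compound 3 `COc1ccc(Nc2ccccn2)cc1` gives 123000 nM in this assay, and compound 2 `COc1ccc(Nc2cc(-c3ccc(C)cc3)ccn2)cc1` gives 33000 nM in this assay. How the core of compound 1 differs from that of compound 3 is not broken down here.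

Going by the values given here, the one counted step within the measured set is from compound 3 to compound 2: 4-methylphenyl in place of hydrogen on an aromatic carbon. This gave a 3.7-fold lower number from compound 3 to compound 2 (0.57 log units; beyond the scatter) in this assay. Compound 1 and compound 2 lie within the scatter of each other, so nothing is said about their order.

Compound 4 `COc1ccc(Nc2nc3ccccc3cc2-c2ccc(C)cc2)cc1` has not yet been measured. It derives from compound 1 by 4-methylphenyl in place of hydrogen on an aromatic carbon. This is the same kind of change as that from compound 3 to compound 2, but not the same: in the earlier pair the entering group sits meta to a group of 9 heavy atoms and opposite the ring nitrogen, whereas in compound 4 it sits ortho to a group of 9 heavy atoms, two atoms from the ring nitrogen, meta to a fused ring and para to a fused ring, on a ring that is part of a fused or bridged system of two rings.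

Resting on compound 1 at 43000 nM and on the size of the step from compound 3 to compound 2, a 3.7-fold lower number from compound 3 to compound 2 (0.57 log units; beyond the scatter), a somewhat smaller step is expected for the differently placed group, a 2.4-fold lower number from compound 1 to compound 4 (0.38 log units; beyond the scatter) in this assay. Compound 4 is therefore estimated at 18000 nM in this assay, expected to fall between 6000 nM and 50000 nM.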

Compound 4, half-maximal inhibitory concentration: 65000 nM
Beside the measured number, compound 4's estimate is 3.6-fold (0.56 log units) below it; measured number above the stated range.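

In this assay, 4-methylphenyl in place of hydrogen on an aromatic carbon gives a 1.5-fold higher number from compound 1 to compound 4 (0.18 log units; within the scatter), so this change produces no readable shift on the core of compound 1. The gain seen on the other core therefore does not carry over as a fixed increment, and the two steps differ in size: the same change on two cores in this assay, a 3.7-fold lower number (0.57 log units; beyond the scatter) from compound 3 to compound 2 and a 1.5-fold higher number (0.18 log units; within the scatter) from compound 1 to compound 4, 5.6-fold (0.75 log units) apart, beyond the scatter of two such steps The core and the placement of the entering group both differ between the two pairs, so these steps neither separate the two factors nor give a general rule for this change across the series, and they say nothing about why the steps differ.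

Still open, going by these compounds, is whether 4-methylphenyl at another aromatic carbon of the core of compound 1 would give a step like the one on the other core, which would help tell placement from core, and whether a methyl group, an amine or a carboxylic acid at the carbon used in compound 4 would give a readable step. All the compounds shown also keep the 4-methoxyphenylamino group, so the effect of a hydroxyl group or a fluorine atom in place of its methoxy group remains open on either core.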